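The source may hold more compounds than are shown below. What is called first, only, known or untested is meant among the compounds shown, and "the series" means these compounds.

Compound 3 (`Oc1ccccc1CNc1ccc(-c2cccc(F)c2)cc1`) stands at the lowest of the two numbers obtained in a functional assay on Jurkat cells (Homo sapiens) for activation, with a stated time of 24 h (on this read-out lower numbers stand for an effect already at smaller amounts and higher numbers for an effect only at larger amounts of compound), with compound 3 giving 2020 nM. Its nearest neighbour is compound 2 (`Cc1ccc(-c2ccc(NCc3ccccc3O)cc2)cc1`), which in this assay gives 3790 nM, and the step of a 1.9-fold lower number from compound 2 to compound 3 (0.27 log units; within the scatter) lies within the scatter, so the two cannot be ranked. Compound 1 (`O=[N+]([O-])c1ccc(NCc2ccccc2O)cc1`) carries a nitro group in place of the second aromatic ring and in this assay compound 1 is reported as "not active" (no number reported).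

Compound 4 (`Oc1ccccc1CNc1ccc(-c2cccc(OCc3ccccc3)c2)cc1`) follows from compound 3 by a single change: benzyloxy in place of fluoro on an aromatic carbon. Among the measured compounds shown here, no measured step exchanges fluoro for benzyloxy, so nothing bears directly on this change. For the measured compounds named here, the only step on the same ring, a 1.9-fold lower number from compound 2 to compound 3 (0.27 log units; within the scatter), is within the scatter, and it tells little about a group as large as benzyloxy. The expectation is therefore a step of a 1.3-fold lower number from compound 3 to compound 4 (0.10 log units; within the scatter) with no firm direction, and a wide range is needed. On this basis compound 4 is expected to give about 1600 nM in this assay, with a range from 400 nM to 6500 nM.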

Compound 4, half-maximal effective concentration: "not active" (no number reported)
No number was reported for compound 4; the estimate stays without a comparison.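

In this assay, among the compounds shown here, compound 4 is reported as "not active" (no number reported) and so no step from compound 3 to compound 4 can be read. The compounds shown leave open whether a group other than fluoro or benzyloxy at this place on the ring would give a number. Nothing among the data shown explains the result for compound 4.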